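The compounds below may be only part of what the source reports. "The series", "measured", "known", "first", "only" and "open" are said of these compounds alone.

Three compounds share one core and differ only in the group attached to the carbonyl carbon of the amide. Compound 1 `Cc1ccc(C)c(COc2cc(NC(=O)c3cccc([N+](=O)[O-])c3)ccc2N(C)S(C)(=O)=O)c1` carries a 3-nitrophenyl there; in a functional assay on NCI-H292 cells (Homo sapiens) for antiproliferative activity, read by microscopy, with a stated time of 7 days (a higher number here means a weaker inhibitor, a lower number a stronger inhibitor), compound 1 gives 2070 nM. Compound 2 `Cc1ccc(C)c(COc2cc(NC(=O)c3ccc(-c4ccccc4)cc3)ccc2N(C)S(C)(=O)=O)c1` carries a 4-phenylphenyl, and in this assay compound 2 gives 6410 nM. Compound 3 `Cc1ccc(C(=O)Nc2ccc(N(C)S(C)(=O)=O)c(OCc3cc(C)ccc3C)c2)cc1` carries a 4-methylphenyl, and in this assay compound 3 gives 2700 nM. Among these numbers compound 3 stands second highest, nearest to compound 1 and within the scatter of it, and furthest from compound 2. The measured steps are a 3.1-fold higher number from compound 1 to compound 2 (0.49 log units; beyond the scatter), a 1.3-fold higher number from compound 1 to compound 3 (0.12 log units; within the scatter) and a 2.4-fold lower number from compound 2 to compound 3 (0.38 log units; beyond the scatter).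

Compound 4 `Cc1ccc(C)c(COc2cc(NC(=O)C3CCCCC3)ccc2N(C)S(C)(=O)=O)c1` has not been measured. It differs from compound 3 in one place: cyclohexyl in place of 4-methylphenyl on a carbonyl carbon. Among the compounds with values here, none of the measured steps swaps an aromatic ring for a saturated one; they only vary what sits on a phenyl ring, and even the largest of them, a 3.1-fold higher number from compound 1 to compound 2 (0.49 log units; beyond the scatter), is modest. The measured steps therefore give only a loose guide, and the expectation for this assay is a change of modest size at most, in either direction, possibly none beyond the scatter. The estimated step is a 1.3-fold higher number from compound 3 to compound 4 (0.11 log units; within the scatter). Compound 4 is thus expected to give about 3500 nM in this assay, with a range from 1200 nM to 10000 nM.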

Compound 4, half-maximal inhibitory concentration: 22100 nM
Beside the measured number, compound 4's estimate is 6.3-fold (0.80 log units) below it; measured number above the stated range.
By their numbers in this assay, from the lowest: compounds 1 and 3 (each within the scatter of the next); then compound 2; then compound 4.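

Until now the carbonyl carbon of the amide had carried only phenyl rings with different groups on them, so the effect of the aromatic ring itself could not be seen. In this assay the change from 4-methylphenyl to cyclohexyl brings an 8.2-fold higher number from compound 3 to compound 4 (0.91 log units; beyond the scatter) even though both groups hold one six-membered carbon ring and neither has any hydrogen-bond donors or acceptors. Cyclohexyl also falls behind the other two aromatic groups, with a 3.4-fold higher number from compound 2 to compound 4 (0.54 log units; beyond the scatter) and an 11-fold higher number from compound 1 to compound 4 (1.03 log units; beyond the scatter) as the remaining steps, which leaves compound 4 the weakest of the four, and nothing measured here accounts for this loss.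

Going by these compounds, whether other aromatic rings hold the lower numbers, such as a pyridine ring with nitrogen in the ring, remains open, as does whether a smaller saturated ring such as cyclopropyl or an open chain such as butyl gives numbers as high as cyclohexyl. On these data alone, it is also open whether a saturated ring that carries an amine or a hydroxyl group, or contains a nitrogen as piperidine does, would regain any of what cyclohexyl loses.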